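From Methylsulfanyl to Fluoro: One Small Swap

This account rests on a few compounds, and the source may have more. Where it says the series, first, only, none or still open, it means among the compounds named here.

Among the measured compounds shown here, only two compounds have been measured so far in a physicochemical assay for solubility, at pH 7.4; a higher number here means a more soluble compound, a lower number a less soluble compound. Compound 1 (`CSc1ccc(NC(=O)Nc2cc(C)nc3ccccc23)cc1`) gives 1300 nM, the higher of the two numbers. Compound 2 (`Cc1cc(NC(=O)Nc2cccc(C(N)=O)c2)c2ccccc2n1`) gives 100 nM, and the gap between the two lies well beyond the usual scatter of repeated measurements.

Compound 3 (`Cc1cc(NC(=O)Nc2ccc(F)cc2)c2ccccc2n1`) has not been measured yet. It keeps the core of compound 1 and alters a single group: fluoro in place of methylsulfanyl on an aromatic carbon. Fluoro takes the place of methylsulfanyl on an aromatic carbon of a six-membered aromatic ring of carbon only, para to a large group.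

For the measured compounds named here, no measured pair shows what this particular swap does, so two values offer only a thin guide. Any forecast here is therefore a cautious one, and its range has to stay wide. In this assay a slight rise is expected, but none beyond the scatter, and the estimated change is a 1.5-fold higher number from compound 1 to compound 3 (0.19 log units; within the scatter). Compound 3 is expected to give about 2000 nM, with an estimated range from 400 nM to 10000 nM.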

Compound 3, solubility: 3700 nM
Estimate against measurement, compound 3: 1.9-fold (0.27 log units) below; the range from low to high includes it.
By their numbers in this assay, from the lowest: compound 2; then compound 1; then compound 3.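

Among the compounds shown here, this is the first measured step at this place on the molecule. In this assay, fluoro in place of methylsulfanyl, on an aromatic carbon of a six-membered aromatic ring of carbon only, para to a large group, gives a 2.8-fold higher number from compound 1 to compound 3 (0.45 log units; beyond the scatter). The step is modest but lies beyond the scatter, so with the rest of the structure held the same, this one small exchange, of 2 heavy atoms for 1 and with 1 hydrogen-bond acceptor fewer, is enough to separate the two compounds. Nothing measured here explains the rise or shows which of those differences matters.

As far as these compounds go, a single pair gives one step in one direction and cannot show a trend across groups at this place, so it remains open whether the rise belongs to fluoro in particular or would also appear with any replacement of methylsulfanyl. Chloro, methoxy or an amine on the same aromatic carbon, each compared directly with compound 1, would show whether the number keeps rising, levels off or falls.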